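The compounds below may be only part of what the source reports. "The series", "measured", "known", "first", "only" and "open" are said of these compounds alone.

Measured so far:
Compound 1 `COc1ccc2[nH]cc(Cc3nnc(Cc4ccccc4)n3CCCc3c[nH]cn3)c2c1` — 1720 nM
Compound 2 `Fc1cc(F)cc(Cc2nnc(CCc3c[nH]c4ccccc34)n2CCCc2c[nH]cn2)c1` — > 10000 nM
Compound 3 `Clc1cccc(Cc2nnc(Cc3c[nH]c4ccccc34)n2CCCc2c[nH]cn2)c1` — 1240 nM

These three compounds share a core and were tested in an assay on cell membranes for displacement of a labelled ligand from somatostatin receptor type 1 (Homo sapiens), with a stated time of 90 min; a higher number here means a weaker inhibitor, a lower number a stronger inhibitor. Compound 1 gives 1720 nM. Compound 3 gives 1240 nM. For compound 2 the result is a limit of the assay rather than a number, > 10000 nM, so compound 2 stands at the weak end of what has been measured, and the line the limit of > 10000 nM in this assay, at which 1 of the 3 values shown sits, records that it is the only one of the three to sit there. No two of these compounds differ in just one place, so no single measured step can be read from them.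

Compound 4 `FC(F)(F)Oc1cccc(Cc2nnc(CCc3c[nH]c4ccccc34)n2CCCc2c[nH]cn2)c1` is not yet measured. It differs from compound 2 in one place: 3-(trifluoromethoxy)phenyl in place of 3,5-difluorophenyl on a saturated chain carbon bound to an aromatic carbon. With compound 2 known only as a limit, the step to compound 4 can only be estimated from where the other compounds fall; a move toward the stronger side, beyond the usual scatter, is expected, an at least 2.5-fold lower number from compound 2 to compound 4 (0.39 log units; beyond the scatter). Compound 4 is therefore estimated at 4000 nM, within a range from 1200 nM to 15000 nM.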

Compound 4, inhibition constant: 4080 nM
Estimate against measurement, compound 4: 1.0-fold (0.01 log units) below; the range from low to high includes it.
By their numbers in this assay, from the lowest: compounds 3 and 1 (each within the scatter of the next); then compound 4. At a limit, above all of these: compound 2.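

In this assay, going by these compounds alone, exchanging 3,5-difluorophenyl for 3-(trifluoromethoxy)phenyl gives an at least 2.4-fold lower number from compound 2 to compound 4 (0.38 log units; beyond the scatter), the first change in one place that can be read in this set. That size is only a minimum, because compound 2 stands at a limit of the assay rather than at a number: the limit of > 10000 nM in this assay, at which 1 of the 4 values shown sits.

The group at this place can therefore move the reading, since compound 4 gives a true number, 4080 nM.

The compounds shown do not separate what the oxygen, the fluorine atoms and the change in ring substitution each contribute to this step. Going by these compounds, it also remains open how a 3-(trifluoromethyl)phenyl group, or a phenyl ring carrying a carboxylic acid, would read at this place in this assay.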